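The source may hold more compounds than are shown below. What is called first, only, known or untested is meant among the compounds shown, and "the series" means these compounds.

Three compounds have been measured in a functional assay on the whole organism with Mus musculus as the target; a higher number here means that more compound is needed for the effect, a lower number that less compound is needed:

Compound 1, `NCC(=O)NCc1nncn1-c1ccc(Cl)cc1C(=O)c1ccccc1`: 1.37 mg/kg
Compound 2, `Cc1nnc(CNC(=O)CN)n1-c1ccc(Cl)cc1C(=O)c1ccccc1F`: 0.09 mg/kg
Compound 3, `CN(C(=O)CNC(=O)CN)c1ccc(Cl)cc1C(=O)c1ccccc1Cl`: 0.56 mg/kg

Among these three numbers compound 3 stands second highest. Its nearest neighbour is compound 1, whose number is higher by a margin beyond the usual scatter, so compound 1 needs more compound for the same effect than compound 3. Compound 2 sits furthest away, with a number lower than that of compound 3 by a margin that is also beyond the scatter, so compound 2 needs the least compound of the three.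

The next compound, compound 4, `CN(C(=O)CNC(=O)CN)c1ccc(Cl)cc1C(=O)c1ccccc1`, differs from compound 3 in one place: hydrogen in place of chloro on an aromatic carbon. Within the data shown here, no pair of measured compounds shows this exact change, so there is nothing to read a step from directly. Among the measured compounds shown here, the only guide is that compound 1, which carries a plain phenyl at the same position on a different core, gives 1.37 mg/kg, while the two compounds with a halogen on that ring give lower numbers. On that basis a moderate step upward in this assay is expected, that is, compound 4 is expected to need more compound than compound 3, by a 2.1-fold higher number from compound 3 to compound 4 (0.33 log units; beyond the scatter). Compound 4 is therefore estimated at 1.2 mg/kg, within a range from 0.4 mg/kg to 4 mg/kg.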

Compound 4, dose for half-maximal effect: 2.16 mg/kg
The estimate for compound 4 lay 1.8-fold (0.26 log units) below the measured number, within the range that was stated.
By their numbers in this assay, from the lowest: compound 2; then compound 3; then compounds 1 and 4 (each within the scatter of the next).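

In this assay, among these compounds, replacing 2-chlorophenyl with phenyl gives a 3.9-fold higher number from compound 3 to compound 4 (0.59 log units; beyond the scatter), the first direct reading of this change with the rest of the molecule held constant. The step is modest but lies beyond the usual scatter, so what sits at this position, on an aromatic carbon ortho to a large group, clearly matters: with the single chlorine atom in place, less compound is needed for the effect, and with hydrogen there, more is needed. Nothing available shows how the chloro group produces this difference, so the pair records the size and direction of the step but gives no explanation for it.

This single pair leaves open whether a bromo, methyl or methoxy group at the same position would match the chloro group, fall short of it or need even less compound. It also leaves open whether the step from 2-chlorophenyl to phenyl would have a similar size on the core of compound 1 or of compound 2, or only on the core shared by compound 3 and compound 4.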